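Swapping chloro for fluoro on the benzylsulfonyl ring

A few compounds are considered here, and "the series" means these few. Any claim that something is new, unique, unknown or untested is made for them only; others in the source may bear on it.

Measured so far in a functional assay on RAW264.7 cells (Mus musculus), read by fluorescence; a lower number here means a stronger inhibitor, a higher number a weaker inhibitor:
- compound 1, `CCOC(=O)C1=CCCCC1NS(=O)(=O)c1ccc(F)cc1Cl`: > 10000 nM, which is a limit of the assay, not a number
- compound 2, `CCOC(=O)C1=CCCCC1S(=O)(=O)Cc1ccc(Cl)cc1F`: 104 nM
- compound 3, `CCOC(=O)C1=CCCCC1S(=O)(=O)Cc1ccc(Cl)cc1`: 101 nM

Compound 2 and compound 3 share a core and differ only in a fluoro group on the aromatic ring; the step of a 1.0-fold lower number from compound 2 to compound 3 (0.01 log units; within the scatter) shows that removing it changes nothing beyond the scatter. Compound 1 sits at the limit of > 10000 nM in this assay, at which 1 of the 3 values shown sits, so it gives no number to compare. Among the two numbers, compound 2 and compound 3 stand together, neither distinguishable from the other.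

Compound 4, `CCOC(=O)C1=CCCCC1S(=O)(=O)Cc1ccc(F)cc1F`, is not yet measured. Its change from compound 2 is fluoro in place of chloro on an aromatic carbon. Among the measured compounds shown here, no measured step swaps one halogen for another, so the only guide is the step from compound 2 to compound 3, which stayed within the scatter when a halogen on this ring was removed. A small step in this assay is therefore expected, with no clear direction. Compound 4 is expected to give about 150 nM, somewhere between 50 nM and 500 nM, a step of a 1.4-fold higher number from compound 2 to compound 4 (0.16 log units; within the scatter).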

Compound 4, half-maximal inhibitory concentration: 14 nM
Compound 4: the middle estimate sits 11-fold (1.03 log units) above what was measured; measured number below the stated range.
By their numbers in this assay, from the lowest: compound 4; then compounds 3 and 2 (each within the scatter of the next). At a limit, above all of these: compound 1.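

In this assay, among the compounds shown here, the group at this place on the ring clearly matters, which the earlier compounds could not show: the change from chloro to fluoro, para to a large group, gives a 7.4-fold lower number from compound 2 to compound 4 (0.87 log units; beyond the scatter). For the compounds shown here, the only earlier step on this ring, a 1.0-fold lower number from compound 2 to compound 3 (0.01 log units; within the scatter), removed the other halogen, the fluoro group, and left the number within the scatter. The two halogen positions therefore do not behave alike in this pair of steps, and a halogen swap at the position para to the large group can move the number beyond the scatter.

Nothing measured here explains why fluoro gives the lower number at this place. A hydrogen, a methyl group or a nitrile at the same carbon would help show whether fluoro helps or chloro hinders, and the compounds shown leave that open.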